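Replacing 4-(pyridin-2-yl)phenyl with 3-chlorophenyl in an antiproliferative series

The compounds below may be only part of what the source reports. "The series", "measured", "known", "first", "only" and "open" are said of these compounds alone.

In a functional assay on HeLa cells (Homo sapiens) for antiproliferative activity, read by CCK-8 assay, with a stated time of 72 h (a higher number here means a weaker inhibitor, a lower number a stronger inhibitor), compound 1 (`Cc1ccc(Nc2nc(Cl)nc3c2ncn3Cc2ccc(C(=O)Nc3ccccc3N)cc2)cc1`) gives 1050 nM and compound 2 (`Nc1ccccc1NC(=O)c1ccc(Cn2cnc3c(Nc4ccccc4)nc(Cl)nc32)cc1`) gives 2920 nM. Compound 3 (`Nc1ccccc1NC(=O)c1ccc(Cn2cnc3c(Nc4ccc(-c5ccccn5)cc4)nc(Cl)nc32)cc1`) reads > 20000 nM, which is a limit of this assay and not a number. Only the limit of > 20000 nM in this assay, at which 1 of the 3 values shown sits, is of this kind, so compound 3 has no exact place on the scale.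

Compound 4 (`Nc1ccccc1NC(=O)c1ccc(Cn2cnc3c(Nc4cccc(Cl)c4)nc(Cl)nc32)cc1`) shares the core of these compounds and differs from compound 3 as follows: 3-chlorophenyl in place of 4-(pyridin-2-yl)phenyl on a nitrogen on an aromatic ring. Among the compounds with values here, three measured steps bear on this change. The pyridin-2-yl group accompanies an at least 19-fold higher number from compound 1 to compound 3 (1.27 log units; beyond the scatter) and an at least 6.8-fold higher number from compound 2 to compound 3 (0.83 log units; beyond the scatter), and compound 4 lacks that group. Compound 4 instead carries a single ring on the nitrogen, as compound 1 and compound 2 do. Among those two, the change on that ring gave only a 2.8-fold higher number from compound 1 to compound 2 (0.44 log units; beyond the scatter). Within the data shown here, no measured compound carries chlorine on that ring, so its contribution remains open. A large step to a lower number is therefore expected, at least as large as the reverse of the step to compound 3 from compound 2. The expected change is an at least 11-fold lower number from compound 3 to compound 4 (1.04 log units; beyond the scatter). Compound 4 is estimated at 1800 nM, with an expected range from 600 nM to 6000 nM.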

Compound 4, half-maximal inhibitory concentration: 11300 nM
For compound 4 the middle estimate is 6.3-fold (0.80 log units) below the measured one; measured number above the stated range.
By their numbers in this assay, from the lowest: compound 1; then compound 2; then compound 4. At a limit, above all of these: compound 3.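

The plain phenyl of compound 2 and the 4-methylphenyl of compound 1 had suggested that a single ring on the nitrogen keeps the number low, but compound 4 shows that this does not hold for every such ring: the chloro group accompanies a 3.9-fold higher number from compound 2 to compound 4 (0.59 log units; beyond the scatter), and the change from 4-methylphenyl to 3-chlorophenyl accompanies an 11-fold higher number from compound 1 to compound 4 (1.03 log units; beyond the scatter). Removing 4-(pyridin-2-yl)phenyl in favour of 3-chlorophenyl gives an at least 1.7-fold lower number from compound 3 to compound 4 (0.24 log units; that floor lies within the scatter), so in this assay this change is not shown to lower the number by more than the usual scatter. The true size of that step stays unknown because compound 3 has only a limit and not a number: the limit of > 20000 nM in this assay, at which 1 of the 4 values shown sits.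

As far as these compounds go, whether the higher number of compound 4 belongs to chlorine itself or to where it sits stays open, since the 3-chlorophenyl and 4-methylphenyl groups carry their substituents at different places on the ring. Also open, from the compounds shown here alone, is how a ring carrying a methoxy group or an amine on the same nitrogen would read in this assay.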